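This account rests on a few compounds, and the source may have more. Where it says the series, first, only, none or still open, it means among the compounds named here.

Measured in a functional assay on the whole organism with Mus musculus as the target, in the formalin test; a higher number here means that more compound is needed for the effect, a lower number that less compound is needed:

- Compound 1 `O=C(c1cc2cc(O)ccc2[nH]1)N1CCC(Cc2ccccc2)CC1`: 1.4 mg/kg
- Compound 2 `O=C(Nc1ccc(O)cc1)C(=O)N1CCC(Cc2ccccc2)CC1`: 9.4 mg/kg
- Compound 3 `O=C(Nc1ccc2[nH]c(O)nc2c1)C(=O)N1CCC(Cc2ccc(F)cc2)CC1`: > 20 mg/kg (a limit)

Across these three compounds, compound 1 gives the lowest measured dose, and compound 2 requires more, at 9.4 mg/kg. Compound 3 has no number of its own, only the limit > 20 mg/kg.

The next compound to be tested is compound 4 `O=C(Nc1ccc2[nH]c(O)nc2c1)C(=O)N1CCC(Cc2ccccc2)CC1`. It differs from compound 3 by hydrogen in place of fluoro on an aromatic carbon, para to a large group, so that 4-fluorobenzyl becomes benzyl (hydrogen in place of fluoro on an aromatic carbon). Among the compounds with values here, no measured pair in this set shows that exchange on its own, which leaves the size of its effect open.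

The nearest guide is compound 2, at 9.4 mg/kg, which carries the same benzyl group and the same pair of carbonyls as compound 4. On that basis, a modest move toward a lower dose is expected, and the assay may still return only a limit. The expected step is an at least 1.4-fold lower number from compound 3 to compound 4 (0.15 log units; that floor lies within the scatter). For compound 4 the estimated dose is 14 mg/kg, with an expected range from 5 mg/kg to 40 mg/kg.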

Compound 4, dose for half-maximal effect: 14 mg/kg
Compound 4: middle estimate and measured number agree at the digits printed; measured number inside the range.
By their numbers in this assay, from the lowest: compound 1; then compounds 2 and 4 (each within the scatter of the next). At a limit, above all of these: compound 3.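

In this assay, the exchange of fluoro for hydrogen on the aromatic carbon para to a large group, which turns 4-fluorobenzyl into benzyl, gives an at least 1.4-fold lower number from compound 3 to compound 4 (0.15 log units; that floor lies within the scatter). Within the data shown here, this is the first pair in the set that isolates this position, and it shows that the compound without fluoro returns a measurable dose while the compound with fluoro does not, with everything else in the two structures held the same. From the compounds shown here alone, compound 3 carries only a limit and not a number, so the step is a floor whose true size stays unknown, and that floor alone does not separate the exchange from the usual scatter: the limit of > 20 mg/kg in this assay, at which 1 of the 4 values shown sits.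

Among these compounds, the pair therefore leaves open how large the effect of removing fluoro really is, and whether it would appear at all on the core of compound 1 or compound 2, where this exchange has no pair. It also leaves open how other groups at this position would behave, such as chloro, methyl or methoxy in place of the hydrogen of compound 4.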